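Swapping Hydroxy for Benzoyl: What to Expect

The source may hold more compounds than are shown below. What is called first, only, known or untested is meant among the compounds shown, and "the series" means these compounds.

In a functional assay for inhibition, with Rattus norvegicus as the target (on this read-out higher numbers stand for weaker inhibition and lower numbers for stronger inhibition), compound 1 `C[C@@H](/N=c1\c(O)c(O)\c1=N/c1ccc(C#N)cc1)C(C)(C)C` gives 370 nM; 24300 nM (2 entries), two entries that lie far apart and so yield no single number. Compound 2 `C[C@@H](/N=c1\c(O)c(O)\c1=N/c1ccc(C#N)cc1O)C(C)(C)C` gives 6050 nM, the only single number shown, and this value falls inside the span of the entries of compound 1. Compound 3 `C[C@@H](/N=c1\c(O)c(O)\c1=N/c1ccc(C#N)cc1C(=O)c1ccccc1)C(C)(C)C` has not yet been measured in this assay. It departs from compound 2 by one change, benzoyl in place of hydroxy on an aromatic carbon. Among the compounds with values here, no step between measured compounds shows what such an exchange does, so the data favour no direction, and the expectation is no shift beyond the usual scatter. The estimated change is a 1.0-fold lower number from compound 2 to compound 3 (0.00 log units; within the scatter), which is expected to stay within that scatter. The range is kept wide because the several entries of compound 1 in this assay, 370 nM; 24300 nM (2 entries) shows how far separate readings of a single compound can part in this test. Compound 3 is estimated at 6000 nM, with an expected range from 900 nM to 35000 nM.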

Compound 3, half-maximal inhibitory concentration: 4780 nM
The estimate for compound 3 lay 1.3-fold (0.10 log units) above the measured number; measured number inside the range.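

In this assay, within the data shown here, the exchange of hydroxy for benzoyl gives a 1.3-fold lower number from compound 2 to compound 3 (0.10 log units; within the scatter), the first step at this position that can be read, and it lies within the scatter. On this aromatic carbon, ortho to a large group and meta to a cyano group, a hydroxy of 1 heavy atom with 1 hydrogen-bond donor thus gave way to a benzoyl of 8 heavy atoms with 0 hydrogen-bond donors and a further six-membered aromatic ring, with no shift that this read-out can separate from repeated measurement. Even that reading has limits, and a modest difference between two compounds would be hard to detect, since separate readings can part widely in this test: the several entries of compound 1 in this assay, 370 nM; 24300 nM (2 entries).

Any step from compound 1 to compound 2 or compound 3 cannot be read, so what the bare position without a substituent contributes remains unsettled. The compounds shown also leave open how an amine, a carboxylic acid or a longer alkyl chain at this aromatic carbon would fare in this assay.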